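The source may hold more compounds than are shown below. What is called first, only, known or untested is meant among the compounds shown, and "the series" means these compounds.

Compound 1 `Cc1cc(/C=C/COC2CCOCC2)cc(=O)o1`: in a functional assay on K562 cells (Homo sapiens) for inhibition (on this read-out lower numbers stand for stronger inhibition and higher numbers for weaker inhibition), compound 1 gives 4000 nM.
Compound 2 `Cc1cc(-c2ccc(Cl)cc2)cc(=O)o1`: in this assay compound 2 gives > 50000 nM, which is a limit of the assay and not a number.
Compound 3 `CCCCC#Cc1cc(C)oc(=O)c1`: in this assay compound 3 gives 15500 nM.

Among these three, compound 2 is the only one whose result is a limit: it sits at the limit of > 50000 nM in this assay, at which 1 of the 3 values shown sits, so no number is known for it, only that it lies beyond what the assay reports. Compound 1 and compound 3 carry chains on the shared core and return numbers; compound 2 carries an aryl ring and does not. No step between two measured compounds differing in a single place is available, so nothing shown connects one change to one shift in this assay.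

Compound 4 `COc1ccc(-c2cc(C)oc(=O)c2)cc1` differs from compound 2 by methoxy in place of chloro on an aromatic carbon. Since compound 2 rests at a limit, the step of an at least 1.1-fold lower number from compound 2 to compound 4 (0.04 log units; that floor lies within the scatter) is expected to be small and is only an estimate. Compound 4 is expected to give about 45000 nM, within a range from 12000 nM to 150000 nM, with a fair chance that this assay again returns only a limit.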

Compound 4, half-maximal inhibitory concentration: > 50000 nM
Compound 4: a limit, no number; the forecaster's own chance of this, stated with the estimate: 55%; at least 1.1-fold (0.04 log units) between middle value and limit.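

In this assay compound 4 gives > 50000 nM, which is a limit and not a number. Compound 2 also rests at a limit, so the step between compound 2 and compound 4 cannot be read. The compounds shown leave open whether methoxy in place of chloro shifts the read-out at all.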